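The source may hold more compounds than are shown below. What is called first, only, known or untested is meant among the compounds shown, and "the series" means these compounds.

Among the compounds with values here, compound 2, whose structure is `CC1=NC(c2cn(S(=O)(=O)c3ccccc3)c3ccc(C)cc23)CN1`, is the weaker of the two compounds measured so far: in an assay on isolated protein for inhibition of kallikrein-7 (Homo sapiens), read by fluorescence, with stated times of 10 min and 30 min (on this read-out lower numbers stand for stronger inhibition and higher numbers for weaker inhibition), compound 2 gives 17000 nM, the highest of the two numbers recorded. Its nearest neighbour is compound 1, with structure `CC1=NC(c2cn(S(=O)(=O)c3ccc(Cl)cc3)c3ccc(C)cc23)CN1`, and in this assay compound 1 gives 1900 nM. Within the data shown here, the one measured step, an 8.9-fold higher number from compound 1 to compound 2 (0.95 log units; beyond the scatter), comes from a hydrogen in place of chloro on an aromatic carbon.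

Compound 3, with structure `CC1=NC(c2cn(S(=O)(=O)c3cccs3)c3ccc(C)cc23)CN1`, differs from compound 2 in a single place: thiophen-2-yl in place of phenyl on a sulfonyl sulfur. Among the measured compounds shown here, no measured step bears on this exchange, since the only step recorded concerns the chloro group and leaves the sulfonyl-bound ring untouched. The change from compound 2 to compound 3 is therefore without a direct precedent among these compounds, and nothing here argues for a shift in either direction beyond the scatter. Compound 3 is consequently expected to stay close to compound 2, with a step of a 1.4-fold lower number from compound 2 to compound 3 (0.15 log units; within the scatter). The estimate for compound 3 in this assay is 12000 nM, with a range from 4000 nM to 40000 nM.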

Compound 3, half-maximal inhibitory concentration: 11000 nM
Compound 3: the middle estimate sits 1.1-fold (0.04 log units) above what was measured; the range from low to high includes it.
By their numbers in this assay, from the lowest: compound 1; then compounds 3 and 2 (each within the scatter of the next).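

In this assay, the exchange on the sulfonyl sulfur shows that a five-membered aromatic ring with one hetero atom can take the place of a six-membered aromatic ring of carbon only with no change beyond the scatter: thiophen-2-yl in place of phenyl gives a 1.5-fold lower number from compound 2 to compound 3 (0.19 log units; within the scatter). The 4-chlorophenyl group stands apart from both, with a 5.8-fold higher number from compound 1 to compound 3 (0.76 log units; beyond the scatter), so compound 1 remains the strongest of the three, and at this position the choice between these two unsubstituted rings matters less than the presence of the chloro group. No measurement shown here accounts for these differences.

The compounds shown leave open whether a chloro group on the thiophen-2-yl ring would bring a change like the one chloro makes on the phenyl ring, seen in an 8.9-fold higher number from compound 1 to compound 2 (0.95 log units; beyond the scatter). They also leave open whether the gain is particular to chloro or would extend to a bromo, methoxy, nitrile or amino group on the phenyl ring, or whether a pyridyl ring on the sulfonyl sulfur would read like phenyl and thiophen-2-yl.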